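A few compounds are considered here, and "the series" means these few. Any claim that something is new, unique, unknown or untested is made for them only; others in the source may bear on it.

Of the compounds shown here, three built on a shared core have so far been measured in an ADME assay on the whole organism (Rattus norvegicus, strain Sprague-Dawley) for pharmacokinetics, at a dose of 2 mg/kg by the oral route; on this read-out higher numbers stand for higher oral bioavailability and lower numbers for lower oral bioavailability. Compound 1 (`CC1(C)CC(c2c[nH]c3c(C(N)=O)cc(-c4ccccc4)cc23)CCS1(=O)=O`) gives 115%, and compound 3 (`NC(=O)c1cc(-c2ccccc2)cc2c(C3CCS(=O)(=O)CC3)c[nH]c12`) gives 97%. Compound 2 (`NC(=O)c1cc(-c2ccccc2)cc2c(C3CCN(S(=O)(=O)CCCN4CCCC4)CC3)c[nH]c12`) gives 12%, the lowest number of the three, and its gap to each of the others lies beyond the usual scatter.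

Compound 4 (`CCS(=O)(=O)N1CCC(c2c[nH]c3c(C(N)=O)cc(-c4ccccc4)cc23)CC1`) has not yet been measured. It differs from compound 2 in one place: hydrogen in place of (pyrrolidin-1-yl)methyl on a saturated chain carbon, two bonds along the chain from a sulfonyl sulfur. In words, this is hydrogen in place of (pyrrolidin-1-yl)methyl on a saturated chain carbon, two bonds along the chain from a sulfonyl sulfur. The (3-(pyrrolidin-1-yl)propyl)sulfonyl group thus becomes ethylsulfonyl.

Going by the values given here, no measured pair shows this change on its own, so any forecast is indirect. Neither compound 1 at 115% nor compound 3 at 97% carries the (pyrrolidin-1-yl)methyl group, but both also differ from compound 2 elsewhere, so they offer only loose guidance. A rise beyond the scatter is expected, with an estimated size of a number 48 percentage points higher from compound 2 to compound 4 (beyond the scatter). Compound 4 is expected to give about 60%, with an estimated range of 30% to 90%.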

Compound 4, oral bioavailability: 58%
Estimate against measurement, compound 4: 2 percentage points above, and the stated range covers the measured number.
By their numbers in this assay, from the lowest: compound 2; then compound 4; then compound 3; then compound 1.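

Going by these compounds alone, the step from one compound to the other gives the first direct reading at this position: in this assay, hydrogen in place of (pyrrolidin-1-yl)methyl on a saturated chain carbon, two bonds along the chain from a sulfonyl sulfur, goes with a number 46 percentage points higher from compound 2 to compound 4 (beyond the scatter) in oral bioavailability. The low number of compound 2, 12% on this read-out, is therefore tied to this one difference and not only to the other places where it differs from the earlier high-scoring compounds, since everything else in this pair is the same and the sulfonyl group stays in place. No measurement at hand explains how the change produces this rise.

The pair shows only the two ends of the change, with the whole (pyrrolidin-1-yl)methyl group present or gone, so it cannot separate the part played by the pyrrolidine ring from that of the chain carrying it. On these data alone, whether a plain propyl chain, a hydroxyl group or a morpholine ring at this place would give a number closer to compound 2 or to compound 4 remains open.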